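Compound 3 to compound 4: a trifluorophenyl exchange

The source may report more compounds than this note shows. Statements on the series, on what has been measured and on what is new or still open speak of the compounds shown alone.

In an ADME assay on BJ cells (Homo sapiens) for cytotoxicity, with a stated time of 72 h (on this read-out lower numbers stand for an effect already at smaller amounts and higher numbers for an effect only at larger amounts of compound), three compounds sharing one core have been measured. Compound 1 `C=C[C@@](C)(/C=C/c1ccc(OC)cc1)CCC=C(C)C` gives > 36600 nM, which is a limit of the assay. Compound 2 `C=C[C@@](C)(/C=C/c1ccc(Nc2ccc(OC(F)(F)F)cc2)cc1)CCC=C(C)C` gives > 36600 nM, again a limit. Compound 3 `C=C[C@@](C)(/C=C/c1ccc(Nc2ccc(F)cc2)cc1)CCC=C(C)C` gives > 36600 nM, also a limit, so it has no number of its own. Going by the values given here, the whole series so far comes down to the limit of > 36600 nM in this assay, at which 3 of the 3 values shown sit.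

Compound 4 `C=C[C@@](C)(/C=C/c1ccc(Nc2cc(F)c(F)c(F)c2)cc1)CCC=C(C)C` departs from compound 3 in one place, with 3,4,5-trifluorophenyl in place of 4-fluorophenyl on a nitrogen on an aromatic ring. Among the compounds with values here, two measured steps bear on this change. One is a step that the two limits leave unreadable from compound 2 to compound 3, with fluoro in place of trifluoromethoxy on an aromatic carbon. The other is a step that the two limits leave unreadable from compound 1 to compound 3, with (4-fluorophenyl)amino in place of methoxy on an aromatic carbon. Neither has a size that can be read, and neither gives a direction.

The expectation rests on compound 3, whose > 36600 nM is a limit, and no step beyond the scatter is expected in this assay. The estimated step is a number no higher from compound 3 to compound 4 (the limit leaves the size open). For compound 4 the expected value is 36600 nM, within an estimated range from 15000 nM to 73000 nM, and the assay may well report only a limit again.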

Compound 4, half-maximal effective concentration: > 36600 nM
Compound 4: only a limit was reported (the forecaster's own chance of this, stated with the estimate: 80%); the middle value sits exactly at the limit.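

Going by these compounds alone, compound 3 and compound 4 both end at a limit in this assay, so no step between them can be read. The series offers one reading only: the limit of > 36600 nM in this assay, at which 4 of the 4 values shown sit.

The compounds shown leave open at what concentration any of them would reach a half-maximal effect, and whether 3,4,5-trifluorophenyl in place of 4-fluorophenyl changes that concentration.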